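This account rests on a few compounds, and the source may have more. Where it says the series, first, only, none or still open, it means among the compounds named here.

Measured so far in a toxicity assay on MT2 cells (Homo sapiens) for cytotoxicity, read by MTT assay; a lower number here means that less compound is tolerated, a higher number that more compound is tolerated:
- compound 1, `N#Cc1cc2c(Oc3ccc(F)cc3OCCn3ccc(=O)[nH]c3=O)cc(F)cn2c1`: 50000 nM
- compound 2, `Cc1c(Oc2ccccc2OCCn2ccc(=O)[nH]c2=O)cc(F)c2ccc(C#N)cc12`: > 100000 nM (a limit of the assay, not a number)
- compound 3, `CCc1cc(Oc2ccccc2OCCn2ccc(=O)[nH]c2=O)c(C)c2cc(C#N)ccc12`: 12000 nM

Compound 3 holds the lower of the two numbers in this assay; compound 1 sits higher, beyond the scatter. For compound 2 only a limit is known in this assay, and one of the three values shown is of that kind (the limit of > 100000 nM in this assay, at which 1 of the 3 values shown sits). Compound 4 is `COc1cc(Oc2ccccc2OCCn2ccc(=O)[nH]c2=O)c(C)c2cc(C#N)ccc12`, not yet measured in this assay. It differs from compound 3 in one place: methoxy in place of ethyl on an aromatic carbon.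

For the measured compounds named here, the one measured step that touches this position is an at least 8.3-fold lower number from compound 2 to compound 3 (0.92 log units; beyond the scatter), an at least modest drop in the number on going to ethyl. Methoxy enters at the same place; no measured pair shows methoxy against ethyl, so the direction rests on that single step. Since ethyl carried the low number, its replacement is expected to move the number back upward in this assay by a modest amount, a 2.1-fold higher number from compound 3 to compound 4 (0.32 log units; beyond the scatter). For compound 4 the expected value in this assay is 25000 nM, with a range from 8000 nM to 80000 nM.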

Compound 4, half-maximal cytotoxic concentration: > 100000 nM
Compound 4 ended at the assay's limit (the forecaster's own chance of this, stated with the estimate: 15%); middle value at least 4.0-fold (0.60 log units) away from the limit.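

In this assay, methoxy in place of ethyl on this aromatic carbon gives an at least 8.3-fold higher number from compound 3 to compound 4 (0.92 log units; beyond the scatter), so ethyl now stands apart from both of the other groups tested at this position. Compound 4 gives > 100000 nM, a limit of the assay and not a number, and compound 2, with fluoro here, also has a limit as its value: the limit of > 100000 nM in this assay, at which 2 of the 4 values shown sit. Among these three compounds, only compound 3, with ethyl, has a measured number, so the lower tolerated concentration goes with ethyl rather than simply with the loss of fluoro.

The step between the two limit compounds cannot be read, which leaves fluoro and methoxy unranked. Going by these compounds, whether a propyl chain, an amine or a hydroxyl on this carbon would track with ethyl or with methoxy remains open.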